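A Benzyl-to-Phenyl Swap on the Amide Nitrogen

A few compounds are considered here, and "the series" means these few. Any claim that something is new, unique, unknown or untested is made for them only; others in the source may bear on it.

Measured compounds:
Compound 1, `C=CC1=C(C(=O)Nc2ccc(C)cc2)C(c2ccc(F)cc2)OC1`: in a functional assay on SW480 cells (Homo sapiens) for cytotoxicity, read by MTT assay, with a stated time of 24 h (on this read-out lower numbers stand for stronger inhibition and higher numbers for weaker inhibition), compound 1 gives > 100000 nM, which is a limit of the assay rather than a number.
Compound 2, `C=CC1=C(C(=O)NCc2ccc(C)cc2)C(c2ccc(OC)cc2)OC1`: in this assay compound 2 gives 31700 nM.

Among the compounds with values here, compound 2 therefore stands as the only compound with an actual number in this assay. Compound 1 sits at the limit of > 100000 nM in this assay, at which 1 of the 2 values shown sits. Within the data shown here, no step between two measured compounds that differ in a single place exists here, since compound 1 and compound 2 differ in two places at once, and their values show only that one is a limit and the other a number.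

The unmeasured compound 3, `C=CC1=C(C(=O)Nc2ccc(C)cc2)C(c2ccc(OC)cc2)OC1`, is reached from compound 2 by one change: 4-methylphenyl in place of 4-methylbenzyl on an amide-type nitrogen. Compound 3 shares its amide nitrogen substituent with compound 1 and its other aryl group with compound 2. Given that compound 1 gives > 100000 nM as a limit, the step from compound 2 to compound 3 is expected to go toward weaker inhibition, beyond the usual scatter, as a 2.5-fold higher number from compound 2 to compound 3 (0.40 log units; beyond the scatter). For compound 3 the expected value in this assay is 80000 nM, with a range from 30000 nM to 200000 nM.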

Compound 3, half-maximal inhibitory concentration: > 100000 nM
Compound 3: only a limit was reported; the forecaster's own chance of this, stated with the estimate: 45%; middle value at least 1.2-fold (0.09 log units) from the limit.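

In this assay, 4-methylphenyl in place of 4-methylbenzyl on the amide-type nitrogen, with the rest of the molecule unchanged, gives an at least 3.1-fold higher number from compound 2 to compound 3 (0.49 log units; beyond the scatter). Within the data shown here, this is the first single-place comparison, and it ties the loss of a readable number to this nitrogen substituent alone, with the methoxy-bearing aryl group held constant. Compound 3 gives > 100000 nM, which is a limit of the assay and not a number, so the step has a floor but no known full size, and the step for methoxy in place of fluoro on an aromatic carbon cannot be read, leaving that change without a readable effect here: the limit of > 100000 nM in this assay, at which 2 of the 3 values shown sit.

The compounds shown leave open whether a longer chain on the same nitrogen, such as 2-phenylethyl, would move the number further toward stronger inhibition than compound 2 does. Also open, as far as these compounds go, is how methoxy and fluoro compare when the amide nitrogen carries 4-methylbenzyl, the one setting in which a number can be read.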